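Methoxy on the amide aryl across two pyridyl-vinyl cores

The source may hold more compounds than are shown below. What is called first, only, known or untested is meant among the compounds shown, and "the series" means these compounds.

Compound 1 `O=C(NCc1ccccc1)c1cc(Oc2ccc(/C=C/c3ccccn3)cc2)ccn1` gives 18800 nM in a functional assay on A549 cells (Homo sapiens) for antiproliferative activity, read by CCK-8 assay, with a stated time of 48 h; a higher number here means a weaker inhibitor, a lower number a stronger inhibitor. Compound 2 `COc1ccc(CNC(=O)c2cc(Oc3ccc(/C=C/c4ccccn4)cc3)ccn2)cc1` differs from it by methoxy in place of hydrogen on an aromatic carbon and gives 63600 nM in this assay; the step is a 3.4-fold higher number from compound 1 to compound 2 (0.53 log units; beyond the scatter). Compound 3 `O=C(Nc1ccccc1)c1cc(Oc2ccc(/C=C/c3ccncc3)cc2)ccn1` carries a core that differs from that of compound 1 in more than one place; the difference between the two cores is not broken down here. In this assay compound 3 gives 79700 nM, the highest number of the three measured, though its gap to compound 2 lies within the scatter. Compound 4 `COc1ccc(NC(=O)c2cc(Oc3ccc(/C=C/c4ccncc4)cc3)ccn2)cc1`, not yet measured, differs from compound 3 by methoxy in place of hydrogen on an aromatic carbon, the same change as from compound 1 to compound 2, at a place described in the same words. Among the measured compounds shown here, only that one earlier instance exists, and it sits on a different core. For compound 4 the expected step is a 2.5-fold higher number from compound 3 to compound 4 (0.40 log units; beyond the scatter) in this assay, resting on the step of a 3.4-fold higher number from compound 1 to compound 2 (0.53 log units; beyond the scatter). Compound 4 is estimated at 200000 nM, between 80000 nM and 500000 nM.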

Compound 4, half-maximal inhibitory concentration: 25600 nM
Estimate against measurement, compound 4: 7.8-fold (0.89 log units) above; measured number outside the range, below it.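

Methoxy in place of hydrogen on an aromatic carbon gives a 3.1-fold lower number from compound 3 to compound 4 (0.49 log units; beyond the scatter) in this assay, so the direction of the earlier step does not hold on the core of compound 3. Set side by side, the two instances of this change run in opposite directions, and the gap between them is larger than scatter alone would account for: the same change on two cores in this assay, a 3.4-fold higher number (0.53 log units; beyond the scatter) from compound 1 to compound 2 and a 3.1-fold lower number (0.49 log units; beyond the scatter) from compound 3 to compound 4, 11-fold (1.02 log units) apart, beyond the scatter of two such steps

On these two cores, the step measured on one therefore gave no reliable guide to the direction on the other, but the result does not show which of the several differences between the cores goes with the reversal, and two instances establish no rule for the series.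

The compounds shown leave open whether another group at the same place, such as an amine or a carboxylic acid, would also separate the two cores. They also leave open how methoxy would behave on a core differing from that of compound 3 in only one place.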